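Shortening the alkyl on the core: compound 3 to compound 4

The compounds below may be only part of what the source reports. "The series", "measured", "known", "first", "only" and "open" are said of these compounds alone.

Measured so far in a functional assay for inhibition of sodium/hydrogen exchanger (Oryctolagus cuniculus); a higher number here means a weaker inhibitor, a lower number a stronger inhibitor:
compound 1 `CCCc1cc(C)c(C(=O)N=C(N)N)cc1S(C)(=O)=O` gives 5.7 nM
compound 2 `Cc1cc(-c2cc(Cl)cc(Cl)c2)c(S(C)(=O)=O)cc1C(=O)N=C(N)N` gives 130 nM
compound 3 `CCc1cc(-n2ccc(=O)cc2)c(S(C)(=O)=O)cc1C(=O)N=C(N)N` gives 930 nM

Compound 3 stands at the highest number of the three in this assay; compound 2 is the nearest, compound 1 the furthest, and both gaps lie beyond the scatter. Within the data shown here, the one measured step, a 23-fold higher number from compound 1 to compound 2 (1.36 log units; beyond the scatter), is large, but it concerns the substituent that compound 3 carries as a different group again, so it does not bear on the change examined here. Compound 4 `Cc1cc(-n2ccc(=O)cc2)c(S(C)(=O)=O)cc1C(=O)N=C(N)N` differs from compound 3 only in that part of the core that compounds 1 and 2 share in the methyl form: hydrogen in place of methyl on a saturated chain carbon bound to an aromatic carbon. Among the measured compounds shown here, no measured pair isolates this methyl-to-ethyl difference, since compounds 1 and 2 differ from compound 3 at two places at once. In the absence of a step on this position, the expectation is that compound 4 stays close to compound 3 in this assay, with a 1.0-fold lower number from compound 3 to compound 4 (0.01 log units; within the scatter) estimated to fall within the scatter. Compound 4 is therefore expected at 900 nM, with a range of 300 nM to 2700 nM.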

Compound 4, half-maximal inhibitory concentration: 75 nM
Compound 4: the middle estimate sits 12-fold (1.08 log units) above what was measured; the whole stated range lies above it.
By their numbers in this assay, from the lowest: compound 1; then compounds 4 and 2 (each within the scatter of the next); then compound 3.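

In this assay this position is clearly not a silent one: ethyl to methyl on the shared core, with nothing else altered, gives a 12-fold lower number from compound 3 to compound 4 (1.09 log units; beyond the scatter), a large step and the first one read on this chain. With methyl on the core, the ring group of 7 heavy atoms in place of propyl on an aromatic carbon still costs a large step, a 13-fold higher number from compound 1 to compound 4 (1.12 log units; beyond the scatter), whereas the same ring group in place of 3,5-dichlorophenyl stays within the scatter, a 1.7-fold lower number from compound 2 to compound 4 (0.24 log units; within the scatter). No supporting measurement accounts for the size of the ethyl to methyl step.

On these data alone, the ethyl to methyl change is read here only with the ring group of 7 heavy atoms on the aromatic carbon, so whether a step of this size also holds with propyl or 3,5-dichlorophenyl there remains open. Also open, as far as these compounds go, is how the number moves with other groups on the core in place of ethyl or methyl, such as chlorine, an amine or cyclopropyl, since this chain is so far read only as a pair.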